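The source may report more compounds than this note shows. Statements on the series, on what has been measured and on what is new or still open speak of the compounds shown alone.

In a functional assay on the whole organism with Canis familiaris (Canis lupus familiaris) as the target (on this read-out higher numbers stand for an effect only at larger amounts of compound and lower numbers for an effect already at smaller amounts), compound 2 `COC(=O)CC/C=C\CC[C@H]1C(=O)C[C@@H](O)[C@@H]1/C=C/C[C@@](C)(O)/C=C/C=C(C)C` gives 0.00006 mg/kg, the highest of the three numbers recorded so far; compound 1 `C/C=C\C=C\[C@](C)(O)C/C=C/[C@H]1[C@H](O)CC(=O)[C@@H]1CC/C=C\CCC(=O)OC` gives 0.0000099 mg/kg and compound 3 `CCCCC(C)(O)C/C=C/[C@H]1[C@H](O)CC(=O)[C@@H]1CC/C=C\CCC(=O)OC` gives 0.000023 mg/kg. Compound 4 `C=C(C)/C=C/[C@](C)(O)C/C=C/[C@H]1[C@H](O)CC(=O)[C@@H]1CC/C=C\CCC(=O)OC` is not yet measured. It differs from compound 2 as follows: 1-methylethenyl in place of 2-methylprop-1-en-1-yl on a double-bonded chain carbon bound to a double-bonded chain carbon. Of the measured steps, a 6.1-fold higher number from compound 1 to compound 2 (0.78 log units; beyond the scatter) acts at the same place, on a double-bonded chain carbon bound to a double-bonded chain carbon, and compound 4 partly undoes that change; the steps of a 2.3-fold higher number from compound 1 to compound 3 (0.37 log units; beyond the scatter) and a 2.6-fold lower number from compound 2 to compound 3 (0.42 log units; beyond the scatter) concern the whole side chain and are smaller. A lower number than compound 2 is therefore expected, beyond the scatter but short of the full step back to compound 1. Compound 4 is estimated at 0.00002 mg/kg, range 0.000007 mg/kg to 0.00006 mg/kg. This corresponds to an expected 3.0-fold lower number from compound 2 to compound 4 (0.48 log units; beyond the scatter).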

Compound 4, dose for half-maximal effect: 0.00002 mg/kg
Beside the measured number, compound 4's estimate shows no gap at the digits printed, and the stated range covers the measured number.
By their numbers in this assay, from the lowest: compound 1; then compounds 4 and 3 (each within the scatter of the next); then compound 2.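

On a double-bonded chain carbon bound to a double-bonded chain carbon in this assay, 1-methylethenyl in place of 2-methylprop-1-en-1-yl gives a 3.0-fold lower number from compound 2 to compound 4 (0.48 log units; beyond the scatter), so the read-out separates these two groups of similar size by name and count. Set against prop-1-en-1-yl, 1-methylethenyl gives a 2.0-fold higher number from compound 1 to compound 4 (0.31 log units; beyond the scatter), placing compound 4 between compound 1 and compound 2 with both steps beyond the scatter. The 1-hydroxy-1,4-dimethylpenta-2,4-dien-1-yl chain is not separated from the saturated chain, with a 1.2-fold lower number from compound 3 to compound 4 (0.06 log units; within the scatter).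

No measurement at hand accounts for these steps. From the compounds shown here alone, how a phenyl or a longer chain at this place would read remains open.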